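Notes on the heteroaryl exchange from compound 2 to compound 3

The source may hold more compounds than are shown below. What is called first, only, known or untested is meant among the compounds shown, and "the series" means these compounds.

Measured so far:
compound 1 `c1ccc(-c2ccncc2)c(OCC2=NCCN2)c1` — < 100000 nM
compound 2 `c1ccc(-c2ccncn2)c(OCC2=NCCN2)c1` — < 100000 nM

In a functional assay for activation of Alpha-1D adrenergic receptor (Homo sapiens), read by calcium flux (on this read-out lower numbers stand for an effect already at smaller amounts and higher numbers for an effect only at larger amounts of compound), compound 1 gives < 100000 nM, which is a limit of the assay and not a number. In this assay compound 2 gives < 100000 nM, again a limit of the assay. Compound 2 thus stands at that limit and nowhere more precise. The step that the two limits leave unreadable from compound 1 to compound 2 stays unreadable because of the limit of < 100000 nM in this assay, at which 2 of the 2 values shown sit. Compound 3 `c1c[nH]c(-c2ccccc2OCC2=NCCN2)c1` differs from compound 2 by 1H-pyrrol-2-yl in place of pyrimidin-4-yl on an aromatic carbon. Among the measured compounds shown here, no measured step bears on this change with a readable size, so neither a size nor a direction beyond the scatter can be derived in this assay. The only anchor is the limit shown by compound 2, < 100000 nM. Compound 3 is expected, with wide uncertainty, at 2000 nM, within 100 nM to 50000 nM. The implied step that the limit leaves unreadable from compound 2 to compound 3 is an expectation only, not supported by any readable measured step.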

Compound 3, half-maximal effective concentration: 6.31 nM
For compound 3 the middle estimate is 320-fold (2.50 log units) above the measured one; measured number below the stated range.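

Among the compounds shown here, no step from compound 1 or compound 2 to compound 3 can be read in this assay, because compound 1 and compound 2 each give a limit and not a number: the limit of < 100000 nM in this assay, at which 2 of the 3 values shown sit. The compounds shown leave open whether 1H-pyrrol-2-yl in place of pyrimidin-4-yl or pyridin-4-yl changes the read-out at all.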